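Working notes on the step from compound 2 to compound 4

This account rests on a few compounds, and the source may have more. Where it says the series, first, only, none or still open, it means among the compounds named here.

The series is tested in an assay on HEK293 cells for positive allosteric modulation of metabotropic glutamate receptor 3 (Rattus norvegicus), read by thallium flux, with a stated time of 2.5 min; on this read-out lower numbers stand for an effect already at smaller amounts and higher numbers for an effect only at larger amounts of compound. Compound 1 `Cc1c(OCCCCOc2ccccc2C(=O)O)ccc(C(=O)CC2CCCC2)c1C` was run, and in this assay compound 1 has "not determined" (no result reported). Compound 3 `CC(=O)c1ccc(OCCCCOc2cccc(C(=O)O)c2C)c(C)c1O` likewise stands in this assay at "not determined" (no result reported). For the measured compounds named here, compound 2 `Cc1c(OCCCCOc2ccc(C(=O)O)cc2Cl)ccc(C(=O)CC2CCCC2)c1O` is the only member with any reading: in this assay compound 2 reaches > 10000 nM, which is a limit of the assay and not a number. Going by the values given here, compound 2 therefore stands at the limit itself, and the only evidence on the series is the limit of > 10000 nM in this assay, at which 1 of the 3 values shown sits. Among the compounds with values here, no step between two measured compounds can be drawn.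

Compound 4 `COc1ccc(C(=O)O)cc1OCCCCOc1ccc(C(=O)CC2CCCC2)c(O)c1C` is not yet measured. It differs from compound 2 in one place: 5-carboxy-2-methoxyphenyl in place of 4-carboxy-2-chlorophenyl on an oxygen on a saturated carbon. Both the carboxy group and the second substituent on that ring change at once, so no single measured comparison speaks to either change.

Given that compound 2 gives only a limit, the step from compound 2 to compound 4 is expected to be small and its direction cannot be told beyond the scatter, estimated as a step that the limit leaves unreadable from compound 2 to compound 4. For compound 4 the estimate in this assay is 15000 nM, in the range from 3000 nM to 60000 nM, with a strong chance that only a limit is again reported.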

Compound 4, half-maximal effective concentration: 1020 nM
The estimate for compound 4 lay 15-fold (1.17 log units) above the measured number; measured number outside the range, below it.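

Of the compounds shown, compound 4 is the only one with a number in this assay, at 1020 nM, so members of this series can give a reading inside the range of the assay. Placing 5-carboxy-2-methoxyphenyl in place of 4-carboxy-2-chlorophenyl on an oxygen on a saturated carbon gives an at least 9.8-fold lower number from compound 2 to compound 4 (0.99 log units; beyond the scatter), which marks this end of the molecule as a place where the read-out responds to change. The true size of the step stays open on one side because compound 2 gives only a limit and not a number: the limit of > 10000 nM in this assay, at which 1 of the 4 values shown sits.

For the compounds shown here, compounds 1 and 3 carry no result, so no step to either can be read, and the one readable step changes the carboxy placement and the second ring substituent at once, leaving open which of the two carries it. Also open, on these data alone, is how a tetrazole or a primary amide in place of the carboxylic acid would read in this assay.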